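Methyl to isopropyl on an amide nitrogen: a second test

The source may hold more compounds than are shown below. What is called first, only, known or untested is meant among the compounds shown, and "the series" means these compounds.

Measured so far:
compound 1 `CCC1C(=O)N(C)c2cnc(-n3ccc4cc(C(=O)NC(C)C)ccc43)nc2N1c1ccn(C)n1`: 22000 nM
compound 2 `CCC1C(=O)N(C)c2cnc(-n3ccc4cc(C(=O)NC)ccc43)nc2N1c1ccn(C)n1`: 43100 nM
compound 3 `CC[C@@H]1C(=O)N(C)c2cnc(-n3ccc4cc(C(=O)NC)ccc43)nc2N1C1CCCC1`: 2200 nM

All three were tested in a functional assay on A549 cells (Homo sapiens) for antiproliferative activity, read by CCK-8 assay, with a stated time of 72 h; on this read-out higher numbers stand for weaker inhibition of growth and lower numbers for stronger inhibition of growth. The change from compound 2 to compound 1 is isopropyl in place of methyl on an amide-type nitrogen, and it gave a 2.0-fold lower number from compound 2 to compound 1 (0.29 log units; within the scatter). Compound 3 shares the amide substituent of compound 2 but differs in its core; that difference between the two cores is not broken down here. Compound 4 `CC[C@@H]1C(=O)N(C)c2cnc(-n3ccc4cc(C(=O)NC(C)C)ccc43)nc2N1C1CCCC1` is not yet measured; it differs from compound 3 by isopropyl in place of methyl on an amide-type nitrogen, at the same place as before, so this is the same change.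

Since the step from compound 2 to compound 1 stayed within the scatter, the expected step in this assay from compound 3 to compound 4 is a 1.7-fold lower number from compound 3 to compound 4 (0.23 log units; within the scatter), resting on a 2.0-fold lower number from compound 2 to compound 1 (0.29 log units; within the scatter). Compound 4 is therefore estimated at 1300 nM, with a likely range from 500 nM to 3500 nM.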

Compound 4, concentration for 50% growth inhibition: 1780 nM
For compound 4 the middle estimate is 1.4-fold (0.14 log units) below the measured one; low and high end bracket the measured number.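

In this assay, isopropyl in place of methyl on the amide-type nitrogen gives a 1.2-fold lower number from compound 3 to compound 4 (0.09 log units; within the scatter), a step too small to count as a real change. Set beside the same change on the other core, the two steps agree: the same change on two cores in this assay, a 2.0-fold lower number (0.29 log units; within the scatter) from compound 2 to compound 1 and a 1.2-fold lower number (0.09 log units; within the scatter) from compound 3 to compound 4, 1.6-fold (0.20 log units) apart, within the scatter of two such steps. This shows that on these two cores the swap left the growth-inhibition number unchanged within the scatter, but it does not show that the swap improves activity, nor that a change with a clear effect would carry from one core to another, and two cores cannot establish a rule for the series.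

The compounds shown leave open whether a longer chain, such as n-butyl, on this nitrogen would move the number beyond the scatter. They also leave open what a carboxylic acid in place of the amide would do.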